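The compounds below may be only part of what the source reports. "The series", "measured", "known", "first", "only" and "open" are said of these compounds alone.

Compound 3 `COc1ccc(-c2ccnc(C(=O)Nc3ccc(Oc4ccnc5[nH]ccc45)c(F)c3)n2)cc1` stands highest of the three numbers in a functional assay on A549 cells (Homo sapiens) for cytotoxicity, read by MTT assay, with a stated time of 72 h; on this read-out lower numbers stand for stronger inhibition and higher numbers for weaker inhibition: compound 3 gives 5430 nM, whereas compound 1 `Cc1ccc(-c2ccnc(C(=O)Nc3ccc(Oc4ccnc5[nH]ccc45)c(F)c3)n2)cc1` gives 1150 nM and compound 2 `O=C(Nc1ccc(Oc2ccnc3[nH]ccc23)c(F)c1)c1nccc(-c2cccc(Cl)c2)n1` gives 450 nM. Compound 4 `O=C(Nc1ccc(Oc2ccnc3[nH]ccc23)c(F)c1)c1nccc(-c2ccc(Cl)cc2)n1` differs from compound 3 by chloro in place of methoxy on an aromatic carbon. Within the data shown here, two measured steps bear on this change. Removing the methoxy gave a 4.7-fold higher number from compound 1 to compound 3 (0.67 log units; beyond the scatter) in reverse, a modest gain; swapping methoxyphenyl for a chlorophenyl gave a 12-fold higher number from compound 2 to compound 3 (1.08 log units; beyond the scatter) in reverse, a large gain, though that chlorine sat at a different position. A large step down in this assay is therefore expected, a 7.2-fold lower number from compound 3 to compound 4 (0.86 log units; beyond the scatter). Compound 4 is estimated at 750 nM in this assay, with a range from 250 nM to 2200 nM.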

Compound 4, half-maximal inhibitory concentration: 8940 nM
Estimate against measurement, compound 4: 12-fold (1.08 log units) below; measured number above the stated range.
By their numbers in this assay, from the lowest: compound 2; then compound 1; then compounds 3 and 4 (each within the scatter of the next).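

In this assay, chloro and methoxy at this place, para to a large group, do not separate (a 1.6-fold higher number from compound 3 to compound 4 (0.22 log units; within the scatter)). The position of the chlorine matters far more than its presence (a 20-fold higher number from compound 2 to compound 4 (1.30 log units; beyond the scatter)), so the low number of compound 2 belongs to the 3-chlorophenyl and does not carry over to chlorophenyl in general. Methyl at this place also stays ahead of chloro (a 7.8-fold higher number from compound 1 to compound 4 (0.89 log units; beyond the scatter)).

No measurement available here accounts for these differences. Open questions are whether 3-methoxyphenyl or 3-methylphenyl would follow the 3-chlorophenyl, and how an amine or a carboxylic acid would fare at this place.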